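Hydrazone series: removing the aryl methyl

A few compounds are considered here, and "the series" means these few. Any claim that something is new, unique, unknown or untested is made for them only; others in the source may bear on it.

Working notes. Three compounds have numbers in a functional assay on T47D cells (Homo sapiens) for cytotoxicity, with a stated time of 72 h, tested at 10 ug/mL; a lower number here means a weaker effect, a higher number a stronger effect of the compound at the concentration tested. Compound 1 `Cc1ccc(N2CCn3c2n[nH]c(=O)c3=O)cc1` carries a fused core and in this assay gives 14%. Compound 3 `Cc1cccc(N2CCn3c2n[nH]c(=O)c3=O)c1C` shares that core and gives 21%. Compound 2 `Cc1ccc(N2CCN/C2=N\N)cc1`, the open hydrazone, gives 12%, a figure that sits within the scatter of both compound 1 and compound 3, so none of the three stands apart from the others on these numbers.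

Compound 4 `N/N=C1\NCCN1c1ccccc1` is not yet measured. It differs from compound 2 in one place: hydrogen in place of methyl on an aromatic carbon. Among the measured compounds shown here, no step between measured compounds isolates this change, so there is no measured reference for it. With every figure so far low and all three within the scatter of one another, the expected step in this assay from compound 2 to compound 4 is a number 2 percentage points lower from compound 2 to compound 4 (within the scatter), that is, no step beyond the scatter in either direction. Compound 4 is thus estimated at 10%, with a range of 2% to 20%.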

Compound 4, a percentage reported as inhibition, at one concentration (the size of the read-out at that concentration, not a potency): 0%
For compound 4 the middle estimate is 10 percentage points above the measured one, and the stated range ends above it.
By their numbers in this assay, from the lowest: compound 4; then compounds 2, 1 and 3 (each within the scatter of the next).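

Hydrogen in place of methyl on an aromatic carbon gives, in this assay, a number 12 percentage points lower from compound 2 to compound 4 (beyond the scatter) as the first step in the series that isolates a single change. The methyl at this place therefore matters to the read-out, even though the step is modest and starts from a low figure: compound 2 gives 12% while compound 4 gives 0% at the concentration tested. No measurement at hand bears on why this one carbon shifts the read-out.

On these data alone, whether an ethyl, a methoxy or a chlorine at the same place would raise the figure above that of compound 2 remains open. Also open is whether the same loss of methyl would carry over to the shared core of compound 1, where a phenyl counterpart is not among the compounds shown.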